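Extending the Fluorinated Tail by One Carbon

A few compounds are considered here, and "the series" means these few. Any claim that something is new, unique, unknown or untested is made for them only; others in the source may bear on it.

Compound 1, `C[C@]1(c2ccc(O)cc2)CSc2cc(O)ccc2[C@H]1CCCCCCCCC(CCCC(F)(F)C(F)(F)F)C(=O)O`, was tested in a functional assay on the whole organism for antagonist activity, with Mus musculus as the target, at a dose of 10 mg/kg by the oral route; on this read-out lower numbers stand for a weaker effect and higher numbers for a stronger effect at the one dose given. In this assay compound 1 gives 77%, the lower of the two numbers in hand. Compound 2, `C[C@]1(c2ccc(O)cc2)CSc2cc(O)ccc2[C@H]1CCCCCCCCC(CCCC(F)(F)C(F)(F)C(F)(F)C(F)(F)F)C(=O)O`, carries a longer fluorinated tail; in this assay compound 2 gives 93%. Among the measured compounds shown here, the only measured step, a number 16 percentage points higher from compound 1 to compound 2 (beyond the scatter), shows that lengthening the fluorinated end of the chain raised the read-out. Compound 3, `C[C@]1(c2ccc(O)cc2)CSc2cc(O)ccc2[C@H]1CCCCCCCCC(CCCCC(F)(F)C(F)(F)F)C(=O)O`, differs from compound 1 by 2,2,3,3,3-pentafluoropropyl in place of 1,1,2,2,2-pentafluoroethyl on a saturated chain carbon, four bonds along the chain from a carbonyl carbon. For the measured compounds named here, this change also lengthens the chain, while the fluorine atoms stay the same in number, so it is a smaller change than the one from compound 1 to compound 2. A step in the same direction but of smaller size is therefore expected, possibly not clearly beyond the scatter. The expected step is a number 6 percentage points higher from compound 1 to compound 3 (within the scatter). Compound 3 is estimated to give 83%, within a range from 66% to 96%.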

Compound 3, a percentage reported as inhibition, in the whole organism at one dose (the size of the read-out at that dose, not a potency): 87%
Compound 3: middle estimate off by 4 percentage points, on the low side, within the range that was stated.
By their numbers in this assay, from the lowest: compounds 1, 3 and 2 (each within the scatter of the next, the first and the last beyond it).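

Putting 2,2,3,3,3-pentafluoropropyl in place of 1,1,2,2,2-pentafluoroethyl on a saturated chain carbon, four bonds along the chain from a carbonyl carbon, gives in this assay a number 10 percentage points higher from compound 1 to compound 3 (within the scatter) at the one dose given. So one more carbon in the chain, with the number of fluorine atoms unchanged, does not clearly separate these two compounds, whereas the step of a number 16 percentage points higher from compound 1 to compound 2 (beyond the scatter) came with a longer fluorinated end. Nothing measured here offers an explanation for either step.

From the compounds shown here alone, what a plain pentyl chain with no fluorine would give at this place remains open, so the share of the fluorine atoms in these numbers cannot be judged. Also open, going by these compounds, is whether a longer link, as in 3,3,4,4,4-pentafluorobutyl, would move the read-out clearly beyond the scatter.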